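Chloro removal on the core: compound 2 to compound 4

This account rests on a few compounds, and the source may have more. Where it says the series, first, only, none or still open, it means among the compounds named here.

Measured compounds:
compound 1 `CCC1(CCCCN2CC=C(c3ccc(Cl)cc3)CC2)C(=O)Nc2ccccc21`, 1.02 nM
compound 2 `CCC1(CCCCN2CCN(c3cccc(Cl)c3)CC2)C(=O)Nc2c(Cl)cc(Cl)cc21`, 9.46 nM
compound 3 `CCC1(CCCCN2CCC(C)CC2)C(=O)Nc2ccccc21`, "not determined" (no result reported)

Series notes. In an assay on CHO cells for displacement of a labelled ligand from 5-hydroxytryptamine receptor 7 (Homo sapiens) (on this read-out higher numbers stand for weaker inhibition and lower numbers for stronger inhibition), compound 1 gives 1.02 nM. In this assay compound 2 gives 9.46 nM, the highest of the two numbers available; compound 1 stands a long way lower, beyond the scatter. Compound 3 `CCC1(CCCCN2CCC(C)CC2)C(=O)Nc2ccccc21` carries a methyl-bearing ring in place of the aryl-bearing amines, and in this assay compound 3 gives "not determined" (no result reported), so no number is available for it. Among the compounds with values here, compound 1 and compound 2 differ in several places at once, so no single-change step connects the two values and nothing can be read off about which change matters.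

Compound 4 `CCC1(CCCCN2CCN(c3cccc(Cl)c3)CC2)C(=O)Nc2ccc(Cl)cc21` is the next case. Relative to compound 2 it shows (hydrogen in place of chloro on an aromatic carbon). The remaining chloro group on the core and the whole amine side stay as in compound 2.

Within the data shown here, no measured pair isolates this change, so the expectation rests on compound 2 alone: its value of 9.46 nM is the anchor. The step from compound 2 to compound 4 is expected to be small, a 1.9-fold lower number from compound 2 to compound 4 (0.28 log units; within the scatter), toward a lower number but possibly within the scatter. For compound 4 the estimate in this assay is 5 nM, in the range 1.5 nM to 16 nM.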

Compound 4, inhibition constant: 8.27 nM
Beside the measured number, compound 4's estimate is 1.7-fold (0.22 log units) below it; low and high end bracket the measured number.
By their numbers in this assay, from the lowest: compound 1; then compounds 4 and 2 (each within the scatter of the next).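

In this assay the series now has its first single-change comparison: a 1.1-fold lower number from compound 2 to compound 4 (0.06 log units; within the scatter) is the whole step, and it lies within the scatter. On this aromatic carbon, ortho to a fused ring and meta to the remaining chloro group, chloro and hydrogen therefore cannot be told apart on this read-out, with the other chloro group on the core and the whole amine side held constant, so the chloro group at this place is not required for a number in this range. Nothing measured in the series bears on why the two compounds read alike.

Still open, on these data alone, is whether this tolerance extends to other groups at this place, such as fluoro, methoxy or nitrile, and whether the remaining chloro group on the core can also give way to hydrogen without a step beyond the scatter. Compound 1 still differs from compound 2 and compound 4 in more than one place, so no single change accounts for its lower number, and the contribution of the amine side remains unresolved.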